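From isopropyl to cyclopentyl: working notes

A few compounds are considered here, and "the series" means these few. Any claim that something is new, unique, unknown or untested is made for them only; others in the source may bear on it.

Measured so far:
- compound 1 `Cc1c(NC(=O)Nc2cnc(-n3nccn3)c(Cl)c2)cnc2ccccc12`: 7170 nM
- compound 2 `CC(C)c1c(NC(=O)Nc2cnc(-n3nccn3)c(Cl)c2)cnc2ccccc12`: 2420 nM

In a functional assay on OCI-Ly3 cells (Homo sapiens) for antiproliferative activity (on this read-out lower numbers stand for an effect already at smaller amounts and higher numbers for an effect only at larger amounts of compound), compound 2 has the lower of the two numbers at 2420 nM, against compound 1 at 7170 nM. The next compound is compound 3 `O=C(Nc1cnc(-n2nccn2)c(Cl)c1)Nc1cnc2ccccc2c1C1CCCC1`, with cyclopentyl in place of isopropyl on an aromatic carbon. Within the data shown here, only one measured step bears on this change: a 3.0-fold lower number from compound 1 to compound 2 (0.47 log units; beyond the scatter), which is modest and beyond the scatter. That step is isopropyl in place of methyl on an aromatic carbon. Among the measured compounds shown here, a single step sets no trend, and no measured compound carries a ring at this place. A smaller step towards lower numbers in this assay is therefore expected, possibly within the scatter. The expected change is a 1.4-fold lower number from compound 2 to compound 3 (0.15 log units; within the scatter). The estimate for compound 3 is 1700 nM, with an expected range from 650 nM to 4500 nM.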

Compound 3, half-maximal effective concentration: 7020 nM
Compound 3: middle estimate off by 4.1-fold (0.62 log units), on the low side, and the stated range ends below it.
By their numbers in this assay, from the lowest: compound 2; then compounds 3 and 1 (each within the scatter of the next).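

In this assay, a larger carbon group at this place does not keep lowering the number: going from isopropyl to cyclopentyl gives a 2.9-fold higher number from compound 2 to compound 3 (0.46 log units; beyond the scatter) and takes back the gain seen from methyl to isopropyl. Cyclopentyl and methyl end up level, with a 1.0-fold lower number from compound 1 to compound 3 (0.01 log units; within the scatter) as the step between them, so isopropyl alone stands apart among these three groups and the read-out does not follow the heavy atom count in a steady way. Nothing at hand explains this reversal. The compounds shown leave open whether the rise belongs to the ring itself or to the larger number of carbons, a question that cyclopropyl and tert-butyl at this place would help to separate. Also open, from the compounds shown here alone, is how an amine or a methoxy group would read here.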